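Trimethoxyphenyl for chlorophenyl on the aromatic-ring nitrogen

A few compounds are considered here, and "the series" means these few. Any claim that something is new, unique, unknown or untested is made for them only; others in the source may bear on it.

Compound 1 `C=CC(=O)Nc1cccc(NC(=O)CSc2nc(Nc3ccccc3)c3ccccc3n2)c1` gives 10200 nM in a functional assay on MDA-MB-231 cells (Homo sapiens) for inhibition, read by MTT assay, with a stated time of 72 h; a lower number here means a stronger inhibitor, a higher number a weaker inhibitor. Compound 2 `C=CC(=O)Nc1cccc(NC(=O)CSc2nc(Nc3ccccc3Cl)c3ccccc3n2)c1` gives 12700 nM, and compound 3 `C=CC(=O)Nc1cccc(NC(=O)CSc2nc(Nc3ccc(Cl)cc3)c3ccccc3n2)c1` gives 10300 nM, which places compound 3 second highest of the three numbers, though all three lie within the scatter of one another. Compound 4 `C=CC(=O)Nc1cccc(NC(=O)CSc2nc(Nc3cc(OC)c(OC)c(OC)c3)c3ccccc3n2)c1` carries 3,4,5-trimethoxyphenyl in place of 4-chlorophenyl on a nitrogen on an aromatic ring. Among the measured compounds shown here, the steps that bear on this change all stayed within the scatter: a 1.2-fold higher number from compound 1 to compound 2 (0.10 log units; within the scatter), a 1.0-fold higher number from compound 1 to compound 3 (0.00 log units; within the scatter) and a 1.2-fold lower number from compound 2 to compound 3 (0.09 log units; within the scatter). Changing the aryl group on that nitrogen has so far moved nothing beyond the scatter, so no step beyond the scatter is expected in this assay, in either direction. Compound 4 is therefore estimated at 10500 nM, with a range from 4000 nM to 28000 nM. This estimate means a 1.0-fold higher number from compound 3 to compound 4 (0.01 log units; within the scatter), which is expected to stay within the scatter.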

Compound 4, half-maximal inhibitory concentration: > 50000 nM
Compound 4 ended at the assay's limit; the forecaster's own chance of this, stated with the estimate: 10%; at least 4.7-fold (0.67 log units) between middle value and limit.
By their numbers in this assay, from the lowest: compounds 1, 3 and 2 (each within the scatter of the next). At a limit, above all of these: compound 4.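

In this assay, the group on a nitrogen on an aromatic ring can move the number beyond the scatter, as shown by an at least 4.8-fold higher number from compound 3 to compound 4 (0.68 log units; beyond the scatter), an at least 3.9-fold higher number from compound 2 to compound 4 (0.59 log units; beyond the scatter) and an at least 4.9-fold higher number from compound 1 to compound 4 (0.69 log units; beyond the scatter). The value of compound 4 is a limit of the assay, not a number: the limit of > 50000 nM in this assay, at which 1 of the 4 values shown sits. Among the compounds shown, only 3,4,5-trimethoxyphenyl gives a step beyond the scatter at this position; phenyl, 2-chlorophenyl and 4-chlorophenyl do not.

Open, going by these compounds, is whether a single methoxy group on that phenyl ring would also give such a step. The same holds for a dimethylamino group or a carboxylic acid there.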